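A cyano swap after three limit readings

The source may hold more compounds than are shown below. What is called first, only, known or untested is meant among the compounds shown, and "the series" means these compounds.

Measured in a functional assay on NCI-H727 cells (Homo sapiens) for antiproliferative activity, with a stated time of 48 h; on this read-out higher numbers stand for weaker inhibition and lower numbers for stronger inhibition:
- compound 1 `CCN(CC)c1ccc(-c2cccc(OC)c2)nn1`: > 25000 nM
- compound 2 `CCN(CC)c1ccc(-c2cccc(Cl)c2)nn1`: > 25000 nM
- compound 3 `CCN(CC)c1ccc(-c2cccc(C(F)(F)F)c2)nn1`: > 25000 nM

These three compounds share one core and differ only in a single group on the outer aromatic ring. All three results take the same form: the limit of > 25000 nM in this assay, at which 3 of the 3 values shown sit. Compound 3 gives > 25000 nM, and this is a limit of the assay, not a number.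

Compound 4 `CCN(CC)c1ccc(-c2cccc(C#N)c2)nn1` keeps the core of compound 3 and changes that one group: cyano in place of trifluoromethyl on an aromatic carbon. Put simply, cyano takes the place of trifluoromethyl on an aromatic carbon.

Three measured swaps at this same carbon bear on the change: a step that the two limits leave unreadable from compound 1 to compound 2, a step that the two limits leave unreadable from compound 1 to compound 3 and a step that the two limits leave unreadable from compound 2 to compound 3. None of them has a size that can be read, so they give no sign that this position can shift the result in either direction. The same limit in this assay is the most likely outcome for the new compound.

The expected step, a step that the limit leaves unreadable from compound 3 to compound 4, is none beyond the usual scatter, with neither direction favoured. For compound 4 the estimated value is 30000 nM, with an expected range of 15000 nM to 60000 nM.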

Compound 4, half-maximal inhibitory concentration: > 25000 nM
Compound 4: a limit, no number; the forecaster's own chance of this, stated with the estimate: 85%; the middle value is on the limit's open side.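

Compound 4 gives > 25000 nM, which is a limit and not a number, so none of its steps from compound 1, compound 2 or compound 3 can be read, because all four results are the same limit: the limit of > 25000 nM in this assay, at which 4 of the 4 values shown sit. These compounds leave open whether any group at this aromatic carbon can produce a measurable value.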